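The compounds below may be only part of what the source reports. "The series", "measured", "known", "first", "only" and "open" are said of these compounds alone.

Compounds measured in a functional assay on MCF7 cells (Homo sapiens) for cytotoxicity, read by CellTiter-Glo, with a stated time of 5 days; a lower number here means a stronger inhibitor, a higher number a weaker inhibitor:

Compound 1 `CC/C(=C(/c1ccc(/C=C/C(=O)O)c(C)c1)c1ccc2[nH]ncc2c1)c1ccccc1`: 14 nM
Compound 2 `CC/C(=C(/c1ccc(/C=C/C(=O)O)cc1)c1ccc2[nH]ncc2c1)c1ccc(Cl)cc1`: 15 nM

Compound 2 stands level with compound 1: their two numbers lie within the usual scatter of each other, so neither can be called the stronger.

Compound 3 `CC/C(=C(/c1ccc(/C=C/C(=O)O)cc1)c1ccc2[nH]ncc2c1)c1ccccc1S(C)(=O)=O` keeps the shared core and swaps one group. It has 2-(methylsulfonyl)phenyl in place of 4-chlorophenyl on a double-bonded chain carbon bound to a double-bonded chain carbon and a saturated chain carbon.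

Going by the values given here, no two measured compounds differ in only one place, so the data offer no direct precedent for this swap and any forecast is loose. A moderate loss of strength in this assay, meaning a higher number, seems the likelier outcome, though a result within the scatter remains possible. The step expected is, as an estimate, a 4.0-fold higher number from compound 2 to compound 3 (0.60 log units; beyond the scatter). For compound 3 the estimated value is 60 nM, with an expected range of 15 nM to 300 nM.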

Compound 3, half-maximal inhibitory concentration: 70 nM
Beside the measured number, compound 3's estimate is 1.2-fold (0.07 log units) below it; measured number inside the range.
By their numbers in this assay, from the lowest: compounds 1 and 2 (each within the scatter of the next); then compound 3.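

Going by these compounds alone, compound 2 and compound 3 differ only on the double-bonded chain carbon bound to a double-bonded chain carbon and a saturated chain carbon, so this is the first change here that can be read on its own. In this assay, 2-(methylsulfonyl)phenyl in place of 4-chlorophenyl gives a 4.7-fold higher number from compound 2 to compound 3 (0.67 log units; beyond the scatter), showing that the group at this position affects the result and that this swap costs strength without removing it. No measurement shown here accounts for the loss.

The swap changes both the substituent and its place on the ring, so the two contributions cannot be separated. From the compounds shown here alone, how a phenyl ring carrying a nitrile or an amine would behave at this position remains open.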